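A few compounds are considered here, and "the series" means these few. Any claim that something is new, unique, unknown or untested is made for them only; others in the source may bear on it.

Measured so far:
compound 1, `CN(C[C@H]1Cc2c(cccc2N2CCN(C3CC3)CC2)CN1)[C@H]1CCCc2cccnc21`: 23.5 nM
compound 2, `Cc1cnc2c(c1)CCC[C@@H]2N(C)C[C@H]1Cc2c(cccc2N2CCNCC2)CN1`: 16.1 nM
compound 3, `CN1CCN(c2cccc3c2C[C@H](CN(C)[C@H]2CCCc4cccnc42)N(C)C3)CC1`: 171 nM

In a functional assay on CCRF-CEM cells for antagonist activity at C-X-C chemokine receptor type 4 (Homo sapiens), read by calcium flux, with stated times of 25 min and 90 s (on this read-out lower numbers stand for stronger inhibition and higher numbers for weaker inhibition), compound 1 gives 23.5 nM. Compound 2 gives 16.1 nM, a number so close that the two cannot be told apart within the usual scatter of this measurement. Compound 3 gives 171 nM, a clearly higher number, well beyond the scatter, so compound 3 is the weaker of the three. Compound 1 therefore sits among the stronger pair.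

The unmeasured compound 4, `CN(C[C@H]1Cc2c(cccc2N2CCN(c3cccc(C(F)(F)F)c3)CC2)CN1)[C@H]1CCCc2cccnc21`, differs from compound 1 in one place: 3-(trifluoromethyl)phenyl in place of cyclopropyl on an amine nitrogen in a ring. Among the measured compounds shown here, the three measured compounds hold no pair that differs only by a change of this kind, so there is no measured step to lean on. A group of this size entering in place of a small ring is the sort of change that often moves the number beyond the scatter, and the expectation here is a moderate step towards a higher number, that is weaker inhibition, in this assay. Compound 4 is expected to give about 60 nM, with a likely range from 15 nM to 250 nM, which means an estimated step of a 2.6-fold higher number from compound 1 to compound 4 (0.41 log units; beyond the scatter).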

Compound 4, half-maximal inhibitory concentration: > 16700 nM
Compound 4: only a limit was reported; the forecaster's own chance of this, stated with the estimate: 5%; middle value at least 270-fold (2.44 log units) away from the limit.
By their numbers in this assay, from the lowest: compounds 2 and 1 (each within the scatter of the next); then compound 3. At a limit, above all of these: compound 4.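

In this assay, placing 3-(trifluoromethyl)phenyl instead of cyclopropyl on the amine nitrogen of the six-membered ring with 2 nitrogen gives an at least 710-fold higher number from compound 1 to compound 4 (2.85 log units; beyond the scatter). Among the compounds shown here, the earlier compounds held no pair differing only at this nitrogen, so this is the first direct sign that the position does not accept every group: the cyclopropyl ring of 3 heavy atoms in compound 1 goes with clear inhibition, while the aromatic group of 10 heavy atoms in compound 4 does not. The reading for compound 4 is a limit and not a number: the limit of > 16700 nM in this assay, at which 1 of the 4 values shown sits.

The compounds shown leave open whether the aromatic ring itself or the trifluoromethyl group on it matters more. A plain phenyl group or a short ethyl chain on the same nitrogen of compound 1 would help to separate these possibilities.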